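The compounds below may be only part of what the source reports. "The series", "measured", "known", "first", "only" and "open" are said of these compounds alone.

Compound 1 `COc1cc(OC)c(-c2coc3cc(OCC=C(C)C)ccc3c2=O)cc1OC`: 1090 nM
Compound 2 `COc1cc(OC)c(-c2coc3cc(OCC(=O)c4cccc(C(F)(F)F)c4)ccc3c2=O)cc1OC`: > 10000 nM, a limit of the assay
Compound 3 `COc1cc(OC)c(-c2coc3cc(OCc4ccc(C#N)cc4)ccc3c2=O)cc1OC`: 7000 nM

Of the two exact numbers in a functional assay on B16 cells (Mus musculus) for antiproliferative activity, read by MTT assay, with a stated time of 24 h (on this read-out lower numbers stand for stronger inhibition and higher numbers for weaker inhibition), compound 3 has the higher one. The gap between them is a 6.4-fold higher number from compound 1 to compound 3 (0.81 log units; beyond the scatter). For compound 2 there is only (the limit of > 10000 nM in this assay, at which 1 of the 3 values shown sits).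

Compound 4 `COc1cc(OC)c(-c2coc3cc(OCc4cccc(Cl)c4)ccc3c2=O)cc1OC` departs from compound 3 by a single exchange: 3-chlorophenyl in place of 4-cyanophenyl on a saturated chain carbon bound to an oxygen on an aromatic ring. It carries 3-chlorophenyl in place of 4-cyanophenyl on a saturated chain carbon bound to an oxygen on an aromatic ring, so (4-cyanobenzyl)oxy gives way to (3-chlorobenzyl)oxy.

Going by the values given here, no measured step makes this exact exchange. The closest is an at least 1.4-fold lower number from compound 2 to compound 3 (0.15 log units; that floor lies within the scatter), which also replaces one aromatic group with another, and its floor lies within the scatter. The larger at least 9.1-fold higher number from compound 1 to compound 2 (0.96 log units; beyond the scatter) replaces 2-methylprop-1-en-1-yl, a different kind of exchange, and so bears on this one only weakly. The expected size of the change is therefore modest, namely a 1.6-fold lower number from compound 3 to compound 4 (0.19 log units; within the scatter), with no step beyond the scatter anticipated. Starting from compound 3 at 7000 nM, the number should stay in the same region. The estimate for compound 4 is 4500 nM, with an expected range from 1500 nM to 12000 nM.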

Compound 4, half-maximal inhibitory concentration: 2280 nM
Beside the measured number, compound 4's estimate is 2.0-fold (0.30 log units) above it, within the range that was stated.
By their numbers in this assay, from the lowest: compound 1; then compound 4; then compound 3. At a limit, above all of these: compound 2.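

On the saturated chain carbon bound to an oxygen on an aromatic ring, the exchange of 4-cyanophenyl for 3-chlorophenyl gives a 3.1-fold lower number from compound 3 to compound 4 (0.49 log units; beyond the scatter) in this assay, which shows that the choice of aromatic group at this place can move the number, a point the earlier step between compound 2 and compound 3 could not settle, as its floor lay within the scatter. Even so, 3-chlorophenyl does not match 2-methylprop-1-en-1-yl at this place, with a 2.1-fold higher number from compound 1 to compound 4 (0.32 log units; beyond the scatter), so compound 1 keeps the lowest number of the four. The step of an at least 4.3-fold lower number from compound 2 to compound 4 (0.64 log units; beyond the scatter) is only a floor, as compound 2 stands at a limit and not at a number: the limit of > 10000 nM in this assay, at which 1 of the 4 values shown sits.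

Since 3-chlorophenyl and 4-cyanophenyl differ both in the group carried on the ring and in where it sits, the compounds shown cannot say which of the two accounts for the step. They also leave open how an amine or a carboxylic acid on that aromatic ring, or a longer chain between the ring and the oxygen, would read in this assay.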